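Aryl amide change from compound 2 to compound 3

The source may report more compounds than this note shows. Statements on the series, on what has been measured and on what is new or still open speak of the compounds shown alone.

In an in vitro ADME assay on microsomes from liver (Mus musculus) for pharmacokinetics, read by LC-MS, with a stated time of 10 min, tested at 1 uM (on this read-out higher numbers stand for fast clearance and lower numbers for slow clearance), compound 1 `CN1C[C@H](C(=O)Nc2cccc(F)c2)[C@@H](c2ccc(/C=C/C(=O)Nc3ccccc3N)cc2)C1` gives 56 mL/min/kg and compound 2 `CN1C[C@H](C(=O)Nc2ccc(F)c(Br)c2)[C@@H](c2ccc(/C=C/C(=O)Nc3ccccc3N)cc2)C1` gives 43 mL/min/kg. Among the compounds with values here, these two numbers lie within the scatter of each other, so compound 2 stands level with compound 1, the only other measured compound. The next structure, compound 3 `Cc1cc(NC(=O)[C@H]2CN(C)C[C@@H]2c2ccc(/C=C/C(=O)Nc3ccccc3N)cc2)ccc1Cl`, differs from compound 2 as follows: 4-chloro-3-methylphenyl in place of 3-bromo-4-fluorophenyl on an amide-type nitrogen. The 4-chloro-3-methylphenyl group has not been measured in any compound. Within the data shown here, the sole measured change on this amide-type nitrogen is a 1.3-fold lower number from compound 1 to compound 2 (0.11 log units; within the scatter), and it stays within the scatter. On that one step, no shift beyond the scatter is expected in this assay, in either direction. The expected change is a 1.1-fold higher number from compound 2 to compound 3 (0.05 log units; within the scatter). For compound 3 the estimated clearance is 48 mL/min/kg, with an expected range of 25 mL/min/kg to 85 mL/min/kg.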

Compound 3, clearance: 65 mL/min/kg
For compound 3 the middle estimate is 1.4-fold (0.13 log units) below the measured one, and the stated range covers the measured number.
By their numbers in this assay, from the lowest: compounds 2, 1 and 3 (each within the scatter of the next).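

In this assay the exchange on the amide-type nitrogen reads a 1.5-fold higher number from compound 2 to compound 3 (0.18 log units; within the scatter) and a 1.2-fold higher number from compound 1 to compound 3 (0.06 log units; within the scatter) and thus adds a third aryl group whose step to each of the other two stays within the scatter. Across 3-fluorophenyl, 3-bromo-4-fluorophenyl and 4-chloro-3-methylphenyl, clearance therefore does not separate, and no compound among these three goes against that reading. Nothing available bears on a cause for these values.

On these data alone, all three groups are halogen-bearing phenyl rings, so it stays open whether a pyridyl ring, a cyclohexyl group or a phenyl ring carrying a carboxylic acid or dimethylamino group would move clearance beyond the scatter. The rest of the shared core is the same in all three compounds, so these notes cannot speak to changes elsewhere.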